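This account rests on a few compounds, and the source may have more. Where it says the series, first, only, none or still open, it means among the compounds named here.

Of the compounds shown here, two that share one core have been measured in a functional assay on Malme-3M cells (Homo sapiens) for cytotoxicity, read by sulforhodamine B assay, with a stated time of 48 h, tested at 10 uM; on this read-out lower numbers stand for a stronger effect and higher numbers for a weaker effect at the one concentration tested. Compound 1 `COc1cc(-c2cc(/C=C/C(=O)c3ccc(N)cc3)[nH]n2)cc(OC)c1OC` gives -45% in this assay, the lowest of the two numbers. Compound 2 `COc1cc(-c2cc(/C=C/C(=O)c3ccc(Cl)c(Cl)c3)[nH]n2)cc(OC)c1OC` gives 72% in this assay, and the step of a number 117 percentage points higher from compound 1 to compound 2 (beyond the scatter) shows how strongly the group on the carbonyl carbon can shift the read-out. Compound 3 `COc1ccc(C(=O)/C=C/c2cc(-c3cc(OC)c(OC)c(OC)c3)n[nH]2)cc1` differs from compound 1 in one place: methoxy in place of amino on an aromatic carbon. Going by the values given here, no measured step makes this exact swap; the only step available, from compound 1 to compound 2, exchanges the whole 4-aminophenyl for 3,4-dichlorophenyl and was large. Among the compounds with values here, since the one change seen at this position weakened the effect strongly, compound 3 is expected to lose some of the effect of compound 1, with an expected step of a number 75 percentage points higher from compound 1 to compound 3 (beyond the scatter). In this assay compound 3 is therefore estimated at 30%, within a range from -30% to 80%.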

Compound 3, a percentage reported as activity, at one concentration (the size of the read-out at that concentration, not a potency): -66%
Compound 3: the middle estimate sits 96 percentage points above what was measured, outside the stated range (below it).
By their numbers in this assay, from the lowest: compound 3; then compound 1; then compound 2.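

In this assay, the change from 4-aminophenyl to 4-methoxyphenyl gives a number 21 percentage points lower from compound 1 to compound 3 (beyond the scatter) and so strengthens the effect: the amino group, with its hydrogen-bond donor, is not required here, since methoxy, with none, does better. The step of a number 138 percentage points lower from compound 2 to compound 3 (beyond the scatter) is far larger and shows that the weak result with 3,4-dichlorophenyl does not hold for every replacement of 4-aminophenyl, so this position accepts some groups and not others. Nothing available explains why these groups differ.

Still open, from the compounds shown here alone, is how a hydroxyl, an ethoxy or a carboxylic acid would read on this aromatic carbon. Also open, going by these compounds, is whether a single chloro group would weaken the effect as the 3,4-dichlorophenyl group does.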